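The source may report more compounds than this note shows. Statements on the series, on what has been measured and on what is new or still open speak of the compounds shown alone.

Compound 2, whose structure is `O=C(CO[N+](=O)[O-])Nc1ccc(C(=O)/C=C/c2ccco2)cc1`, is the lower of the two compounds measured in a functional assay on the whole organism (strain albino) for inhibition, with Rattus norvegicus as the target, read by paw edema, with stated times of 30 min and 5 h, at a dose of 100 mg/kg by the oral route; on this read-out higher numbers stand for more inhibition at the one dose given (going by the name of the read-out) and lower numbers for less inhibition: compound 2 gives 39%, while compound 1, with the structure `O=C(CO[N+](=O)[O-])Nc1ccc(C(=O)/C=C/c2ccc(Cl)cc2)cc1`, gives 60%. For the measured compounds named here, the one measured step, a number 21 percentage points lower from compound 1 to compound 2 (beyond the scatter), concerns the furan-2-yl in place of 4-chlorophenyl at the far end of the shared core and leaves the nitrooxy-bearing amide untouched.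

Compound 3, with the structure `CC(O[N+](=O)[O-])C(=O)Nc1ccc(C(=O)/C=C/c2ccco2)cc1`, keeps the furan-2-yl end of compound 2 and differs from it only at that amide side chain: methyl in place of hydrogen on a saturated chain carbon bound to a carbonyl carbon and an oxygen on an unsaturated carbon. Going by the values given here, no measured step bears on a change of this kind, since the only step known here lies at the other end of the molecule. Without any shown step at this position, compound 3 is expected to stay close to compound 2, with a step of a number 1 percentage points higher from compound 2 to compound 3 (within the scatter) that is not expected to exceed the usual scatter. The estimate for compound 3 in this assay is therefore 40%, within a range from 25% to 55%.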

Compound 3, a percentage reported as inhibition, in the whole organism at one dose (the size of the read-out at that dose, not a potency): 49%
For compound 3 the middle estimate is 9 percentage points below the measured one, within the range that was stated.
By their numbers in this assay, from the lowest: compounds 2 and 3 (each within the scatter of the next); then compound 1.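

In this assay, for the compounds shown here, the amide side chain is reached for the first time by the step of a number 10 percentage points higher from compound 2 to compound 3 (within the scatter) and, with the furan-2-yl end held fixed, this read-out does not tell (nitrooxy)methyl from 1-(nitrooxy)ethyl. The earlier step of a number 21 percentage points lower from compound 1 to compound 2 (beyond the scatter) at the far end of the molecule lies beyond the scatter, whereas methyl in place of hydrogen on this saturated chain carbon bound to a carbonyl carbon and an oxygen on an unsaturated carbon stays within it, so this position accepts the added methyl at the one dose given, at least on the furan-2-yl compounds. Nothing at hand offers an explanation for this result.

The compounds shown leave open what a longer chain such as ethyl in place of the methyl, or a hydroxyl or an amine in place of the nitrooxy group, would give in this assay at this position. They also leave open whether the same methyl would read alike on the 4-chlorophenyl end of compound 1, where the starting number is higher.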